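Adding a Second Chloro to a Rearranged Purine Core

A few compounds are considered here, and "the series" means these few. Any claim that something is new, unique, unknown or untested is made for them only; others in the source may bear on it.

Of the compounds shown here, three have been tested in a functional assay on OVCAR-4 cells (Homo sapiens) for cytotoxicity, read by sulforhodamine B assay, with a stated time of 48 h; on this read-out higher numbers stand for weaker inhibition of growth and lower numbers for stronger inhibition of growth. Compound 2 `ClCc1ccccc1Cn1cnc2c(Cl)ncnc21` gives 3380 nM, and compound 1 `ClCc1ccccc1Cn1cnc2c(Cl)nc(Cl)nc21` gives 1770 nM. The difference between them is chloro in place of hydrogen on an aromatic carbon, and the step was a 1.9-fold lower number from compound 2 to compound 1 (0.28 log units; within the scatter). Compound 3 `ClCc1ccccc1Cn1cnc2ncnc(Cl)c21` gives 4890 nM; it shares its atoms with compound 2, but the difference between the two cores is not broken down here.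

Compound 4 `ClCc1ccccc1Cn1cnc2nc(Cl)nc(Cl)c21` has not yet been measured. It differs from compound 3 by chloro in place of hydrogen on an aromatic carbon, the same change that separates compound 2 from compound 1. Because a 1.9-fold lower number from compound 2 to compound 1 (0.28 log units; within the scatter) stayed within the scatter, a similarly small step is expected here as well. In this assay the step from compound 3 to compound 4 is estimated as a 1.9-fold lower number from compound 3 to compound 4 (0.27 log units; within the scatter). Compound 4 is therefore expected to give about 2600 nM, likely between 1200 nM and 5500 nM.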

Compound 4, concentration for 50% growth inhibition: 2130 nM
Estimate against measurement, compound 4: 1.2-fold (0.09 log units) above, and the stated range covers the measured number.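

In this assay, putting a chloro group on the aromatic carbon between two ring nitrogen atoms gives a 2.3-fold lower number from compound 3 to compound 4 (0.36 log units; beyond the scatter), a modest step. Set beside the earlier step, the same change looks much the same on both cores: the same change on two cores in this assay, a 1.9-fold lower number (0.28 log units; within the scatter) from compound 2 to compound 1 and a 2.3-fold lower number (0.36 log units; beyond the scatter) from compound 3 to compound 4, 1.2-fold (0.08 log units) apart, within the scatter of two such steps. Among the compounds shown here, this rests on only two pairs of compounds in one cell line, so it does not show that the step would hold on any other core.

The compounds shown carry only hydrogen or chloro at this place, so the effect of an amine, a methoxy group or a longer chain there remains open. Whether any of these would behave alike on both cores is also unanswered.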